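Cytotoxicity series: methyl added to the core chain

The source may report more compounds than this note shows. Statements on the series, on what has been measured and on what is new or still open speak of the compounds shown alone.

Compound 1 `CCOC(=O)CSc1nnc(C)n1N1C(=O)c2ccccc2C1=O` and compound 2 `C#CCSc1nnc(C)n1N1C(=O)c2ccccc2C1=O` share one core and differ only at the saturated chain carbon bound to a sulfur. In a functional assay on HepG2 cells (Homo sapiens) for cytotoxicity, read by MTT assay, with a stated time of 48 h (on this read-out higher numbers stand for weaker inhibition and lower numbers for stronger inhibition), compound 1 gives > 200000 nM, which is a limit of the assay and not a number. In this assay compound 2 gives > 200000 nM, again a limit rather than a number. The step that the two limits leave unreadable from compound 1 to compound 2 is therefore of unreadable size. Compound 2 thus stands at the limit of > 200000 nM in this assay, at which 2 of the 2 values shown sit.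

Compound 3 `C#CCSc1nnc(CC)n1N1C(=O)c2ccccc2C1=O` differs from compound 2 by methyl in place of hydrogen on a saturated chain carbon bound to an aromatic carbon. No measured step touches that place, and the only step shown is unreadable, so no direction can be taken from it. The expected step that the limit leaves unreadable from compound 2 to compound 3 is none beyond the scatter. Compound 3 is accordingly expected at 300000 nM, within 100000 nM to 1000000 nM, and most likely reported again only as a limit.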

Compound 3, half-maximal inhibitory concentration: > 200000 nM
Compound 3: only a limit was reported; the forecaster's own chance of this, stated with the estimate: 80%; the middle value lies beyond the limit too.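

Compound 3 gives > 200000 nM in this assay, which is a limit and not a number, so no new step can be read from compound 2 to compound 3. The compounds shown leave open whether any change to the shared core moves the read-out, as all stand at one point: the limit of > 200000 nM in this assay, at which 3 of the 3 values shown sit.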